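The source may hold more compounds than are shown below. What is called first, only, known or untested is meant among the compounds shown, and "the series" means these compounds.

Measured in a functional assay on HCT-116 cells (Homo sapiens) for antiproliferative activity, with a stated time of 48 h; on this read-out higher numbers stand for weaker inhibition and lower numbers for stronger inhibition:
- Compound 1 `CCOC(=O)c1ccc(-c2ccc(N(CC)CC)nn2)cc1`: 500 nM
- Compound 2 `FC(F)(F)c1cccc(-c2ccc(N3CCCC3)nn2)c1`: > 25000 nM (a limit of the assay, not a number)
- Compound 3 `CCOC(=O)c1ccc(-c2ccc(OCC)nn2)cc1`: > 25000 nM (a limit of the assay, not a number)

Compound 3 therefore has no exact value and sits at the assay's limit. More broadly, the data show (the limit of > 25000 nM in this assay, at which 2 of the 3 values shown sit).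

Compound 4 `CCCCOc1ccc(-c2ccc(C(=O)OCC)cc2)nn1` differs from compound 3 by ethyl in place of hydrogen on a saturated chain carbon, two bonds along the chain from an oxygen on an aromatic ring, so ethoxy becomes butoxy. For the measured compounds named here, the only measured step touching this group is an at least 50-fold higher number from compound 1 to compound 3 (1.69 log units; beyond the scatter), a large loss of activity on putting ethoxy in place of diethylamino. Going by the values given here, no measured step shows what lengthening the ethoxy chain does. Compound 4 also lacks the diethylamino group, so the loss seen in an at least 50-fold higher number from compound 1 to compound 3 (1.69 log units; beyond the scatter) is expected to persist. Some recovery of activity remains possible, but the expected change is a number no higher from compound 3 to compound 4 (the limit leaves the size open), with nothing beyond the scatter. For compound 4, the estimated value is 25000 nM, with an expected range from 6000 nM to 40000 nM, and a reading at the limit is likely.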

Compound 4, half-maximal inhibitory concentration: > 25000 nM
Compound 4: no number, only a limit; the forecaster's own chance of this, stated with the estimate: 70%; the middle value sits exactly at the limit.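

In this assay compound 4 gives > 25000 nM, which is a limit of the assay and not a number. Lengthening ethoxy to butoxy brings no activity back into the measurable range, and without the diethylamino group the large loss stays: an at least 50-fold higher number from compound 1 to compound 4 (1.69 log units; beyond the scatter). The step from compound 3 to compound 4 cannot be read, and ethoxy and butoxy now end at the same ceiling: the limit of > 25000 nM in this assay, at which 3 of the 4 values shown sit.

As far as these compounds go, whether any other group on this aromatic carbon of the core of compound 1 could restore activity stays open, for instance a dimethylamino group, a piperidine ring or a diethylamino group with longer chains on its nitrogen. From the compounds shown here alone, how weak compound 3 and compound 4 really are, and whether they differ at all, also stays open.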